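Prop-1-yn-1-yl to but-1-yn-1-yl: notes on compound 4

A few compounds are considered here, and "the series" means these few. Any claim that something is new, unique, unknown or untested is made for them only; others in the source may bear on it.

In an ADME assay on L1210/0 cells (Mus musculus) for cytotoxicity, with a stated time of 48 h (a higher number here means a weaker inhibitor, a lower number a stronger inhibitor), compound 1 (`[N-]=[N+]=NCc1cn([C@H]2C[C@H](O)[C@@H](CO)O2)c(=O)[nH]c1=O`) gives 124000 nM as a measured number. Compound 2 (`O=c1[nH]c(=O)n([C@H]2C[C@H](O)[C@@H](CO)O2)cc1C#CCO`) gives only a limit (> 200000 nM). Compound 3 (`CC#Cc1cn([C@H]2C[C@H](O)[C@@H](CO)O2)c(=O)[nH]c1=O`) also gives only a limit (> 200000 nM). Compound 3 thus stands at the limit of > 200000 nM in this assay, at which 2 of the 3 values shown sit, and has no exact number.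

Compound 4 (`CCC#Cc1cn([C@H]2C[C@H](O)[C@@H](CO)O2)c(=O)[nH]c1=O`) follows from compound 3 through (methyl in place of hydrogen on a saturated chain carbon bound to a triple-bonded carbon), methyl in place of hydrogen on a saturated chain carbon bound to a triple-bonded carbon. The step at that same place reads a step that the two limits leave unreadable from compound 2 to compound 3 and gives no size. The other steps, an at least 1.6-fold higher number from compound 1 to compound 2 (0.20 log units; that floor lies within the scatter) and an at least 1.6-fold higher number from compound 1 to compound 3 (0.20 log units; that floor lies within the scatter), show only floors within the scatter. No change beyond the scatter is therefore expected in this assay, and the expected step reads a number no higher from compound 3 to compound 4 (the limit leaves the size open) here. For compound 4 the estimate is 200000 nM, with an expected range from 90000 nM to 400000 nM.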

Compound 4, half-maximal inhibitory concentration: > 200000 nM
Compound 4: no number, only a limit; the forecaster's own chance of this, stated with the estimate: 70%; the middle value lies on the limit itself.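

In this assay compound 4, with but-1-yn-1-yl at this position, gives > 200000 nM, which is a limit and not a number. Among these compounds, the steps to compound 4 from compound 2 and compound 3 cannot be read, and the only readable step is an at least 1.6-fold higher number from compound 1 to compound 4 (0.20 log units; that floor lies within the scatter). Adding methyl thus yields no exact number, and the limit now covers most of the series: the limit of > 200000 nM in this assay, at which 3 of the 4 values shown sit.

As far as these compounds go, whether any triple-bonded group at this position gives a measurable number remains open. Also open, from the compounds shown here alone, is how an amine or a longer chain in place of but-1-yn-1-yl would read in this assay.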